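A few compounds are considered here, and "the series" means these few. Any claim that something is new, unique, unknown or untested is made for them only; others in the source may bear on it.

Compound 1 `COc1ccccc1C1=NC(c2ccccc2)CO1` gives 3.76
Compound 2 `Cc1ccccc1C1=NC(c2ccccc2)CO1` gives 3.68
Compound 3 `CSc1ccccc1C1=NC(c2ccccc2)CO1` gives 3.5

These three compounds were measured in a physicochemical assay for lipophilicity (a higher number here means a more lipophilic compound, a lower number a more polar compound), and they lie close together. Compound 3 , at 3.5, stands within the scatter of both others. The measured steps to it are a number 0.26 log units lower from compound 1 to compound 3 (within the scatter) and a number 0.18 log units lower from compound 2 to compound 3 (within the scatter).

The next compound is compound 4 `FC(F)(F)c1ccccc1C1=NC(c2ccccc2)CO1`, which has trifluoromethyl in place of methylsulfanyl on an aromatic carbon, ortho to a large group: trifluoromethyl in place of methylsulfanyl on an aromatic carbon.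

Within the data shown here, no measured step involves trifluoromethyl, so the evidence is indirect. The closest guide is the three swaps at this same place, which include a number 0.08 log units lower from compound 1 to compound 2 (within the scatter) as well as the two steps above. None of them goes beyond the scatter. A small step is therefore expected here too, perhaps slightly upward, although the data do not settle the direction. The estimated step is a number 0.30 log units higher from compound 3 to compound 4 (within the scatter). For compound 4 the estimated value is 3.8, with an expected range from 3.45 to 4.15.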

Compound 4, partition coefficient: 3.71
For compound 4 the middle estimate is 0.09 log units above the measured one; low and high end bracket the measured number.
By their numbers in this assay, from the lowest: compounds 3, 2, 4 and 1 (each within the scatter of the next).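

In this assay, trifluoromethyl on this aromatic carbon, ortho to a large group, stays within the scatter of all three earlier groups: a number 0.21 log units higher from compound 3 to compound 4 (within the scatter), a number 0.03 log units higher from compound 2 to compound 4 (within the scatter) and a number 0.05 log units lower from compound 1 to compound 4 (within the scatter). The earlier swaps had already stayed this close, but this one goes further in makeup, since trifluoromethyl brings 4 heavy atoms and 0 hydrogen-bond acceptors where methylsulfanyl had 2 heavy atoms and 1 hydrogen-bond acceptor, so all four groups now read alike at this position. Nothing measured here explains why they do.

As far as these compounds go, whether an amine or a carboxylic acid at this same place would also stay within the scatter remains open. So does whether these four groups would read alike at another place on the ring.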